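The compounds below may be only part of what the source reports. "The series", "measured", "known", "first", "only" and "open" are said of these compounds alone.

Measured compounds:
Compound 1, `CCOC(=O)C1=Cc2ccccc2OC1(OCc1cn(CC(=O)Nc2cccc(Cl)c2)nn1)C(F)(F)F`, in a functional assay on A549 cells (Homo sapiens) for inhibition, read by MTT assay, with a stated time of 24 h; a lower number here means a stronger inhibitor, a higher number a weaker inhibitor: 12800 nM
Compound 2, `CCOC(=O)C1=Cc2ccccc2OC1(OCc1cn(CC(=O)Nc2ccc(C)cc2)nn1)C(F)(F)F`, in this assay: 54300 nM

Compound 2 gives the highest of the two numbers in this assay; its nearest neighbour is compound 1, and the step of a 4.2-fold higher number from compound 1 to compound 2 (0.63 log units; beyond the scatter) lies beyond the scatter, though it is modest. Compound 3, `CCOC(=O)C1=Cc2ccccc2OC1(OCc1cn(CC(=O)Nc2ccc(OC)cc2)nn1)C(F)(F)F`, has not yet been measured. It differs from compound 2 in one place: methoxy in place of methyl on an aromatic carbon. Among the measured compounds shown here, no measured pair covers this exchange of methyl for methoxy. For the measured compounds named here, the only step available concerns a different exchange on the same anilide ring, a 4.2-fold higher number from compound 1 to compound 2 (0.63 log units; beyond the scatter), and it shows that a change of substituent there can move the number by a modest amount. With nothing measured for the methoxy group itself, the step expected for compound 3 is a 1.1-fold lower number from compound 2 to compound 3 (0.04 log units; within the scatter), small and within the scatter, with no direction favoured. Compound 3 is therefore estimated at 50000 nM in this assay, with a range from 20000 nM to 120000 nM that allows for a modest shift either way.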

Compound 3, half-maximal inhibitory concentration: 29400 nM
Compound 3: middle estimate off by 1.7-fold (0.23 log units), on the high side; the measured number falls inside the stated range.
By their numbers in this assay, from the lowest: compound 1; then compounds 3 and 2 (each within the scatter of the next).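

In this assay, going from 4-methylphenyl to 4-methoxyphenyl adds an oxygen and a hydrogen-bond acceptor at the place para to a large group, yet the read-out does not separate the two compounds (a 1.8-fold lower number from compound 2 to compound 3 (0.27 log units; within the scatter)). The new comparison with the 3-chlorophenyl compound still stands clear of the scatter (a 2.3-fold higher number from compound 1 to compound 3 (0.36 log units; beyond the scatter)), so compound 1 remains the strongest inhibitor of the three, and both 4-substituted compounds now lie on the same side of it. Nothing available explains why the numbers fall this way.

The three compounds leave open whether the gap to compound 1 follows the chlorine itself or its place on the ring, since the group and its place change together in each comparison with compound 1, and a 4-chlorophenyl or a 3-methoxyphenyl group would be needed to pull the two apart. They also leave open how far the number can move at the place para to a large group with a dimethylamino group or a carboxylic acid, which differ more from methyl than methoxy does in what they carry.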